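Swapping a Propyl Amide for a Cyclopentylmethyl Urea

The compounds below may be only part of what the source reports. "The series", "measured", "known", "first", "only" and "open" are said of these compounds alone.

Three compounds have been measured in a functional assay on M21 cells (Homo sapiens) for antiproliferative activity, read by sulforhodamine B assay, with a stated time of 48 h; on this read-out higher numbers stand for weaker inhibition and lower numbers for stronger inhibition:

Compound 1, `CCCC(=O)Nc1ccc(S(=O)(=O)Oc2ccccc2C(C)C)cc1`: 6100 nM
Compound 2, `CCCC(=O)Nc1ccc(S(=O)(=O)Oc2ccccc2I)cc1`: 9000 nM
Compound 3, `CC(C)c1ccccc1OS(=O)(=O)c1ccc(NC(=O)NC2CCCC2)cc1`: 6100 nM

Compound 2 carries an iodo group on its phenyl ester ring where compound 1 carries isopropyl, and the step of a 1.5-fold higher number from compound 1 to compound 2 (0.17 log units; within the scatter) shows that this swap did not move the number beyond the scatter. Compound 2 therefore cannot be told apart from compound 1 or compound 3 on these readings.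

Compound 4, `O=C(NCC1CCCC1)Nc1ccc(S(=O)(=O)Oc2ccccc2I)cc1`, differs from compound 2 in one place: (cyclopentylmethyl)amino in place of propyl on a carbonyl carbon. Among the measured compounds shown here, the closest precedent is the step of no change at the digits printed from compound 1 to compound 3 (within the scatter), where a cyclopentylamino group replaced propyl on the same carbonyl carbon with the isopropyl core and left the number where it was. The present change differs only by one extra carbon in the chain, so the expectation is a step of about no change at the digits printed from compound 2 to compound 4 (within the scatter), nothing beyond the scatter. Compound 4 is estimated at 9000 nM, with a range from 4000 nM to 20000 nM.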

Compound 4, half-maximal inhibitory concentration: 7600 nM
Beside the measured number, compound 4's estimate is 1.2-fold (0.07 log units) above it; the range from low to high includes it.
By their numbers in this assay, from the lowest: compounds 1, 3, 4 and 2 (each within the scatter of the next).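

In this assay, the larger (cyclopentylmethyl)amino group in place of propyl on the carbonyl carbon gives a 1.2-fold lower number from compound 2 to compound 4 (0.07 log units; within the scatter). The earlier tolerance of such a swap came only from the isopropyl pair, compound 1 and compound 3, and the same kind of change now also leaves the number within the scatter in an iodo pair. Adding a five-membered carbon ring and a hydrogen-bond donor at this place therefore did not shift the reading beyond the scatter in either pair, and no available evidence accounts for this.

On these data alone, whether any group on this carbonyl carbon can move the number beyond the scatter remains open. A carboxylic acid, an amine or a much longer chain there would test this, as would a phenyl ring in place of the cyclopentyl ring.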